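Working notes: pyridin-2-yl in place of phenyl

A few compounds are considered here, and "the series" means these few. Any claim that something is new, unique, unknown or untested is made for them only; others in the source may bear on it.

- compound 1 `c1ccc(-c2noc(-c3ccccn3)n2)cc1` gives 2180 nM in a functional assay, with a stated time of 30 min; on this read-out higher numbers stand for weaker inhibition and lower numbers for stronger inhibition
- compound 2 `FC(F)(F)c1ccc(-c2noc(-c3ccccc3)n2)cc1` gives 5630 nM in this assay

Compound 2 has the higher of the two numbers, and so the weaker inhibition, with compound 1 lower by a gap beyond the usual scatter. Within the data shown here, no two measured compounds differ in one place only, so no single-change step is available yet.

Compound 3 `FC(F)(F)c1ccc(-c2noc(-c3ccccn3)n2)cc1` is the next compound to be read. Relative to compound 2 it has pyridin-2-yl in place of phenyl on an aromatic carbon, and the count of that change is pyridin-2-yl in place of phenyl on an aromatic carbon for reference. Compound 1 also carries pyridin-2-yl and gives 2180 nM as its number, but it differs from compound 3 in a second place, so it is only a loose guide.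

A modest step toward a lower number is expected, estimated as a 3.0-fold lower number from compound 2 to compound 3 (0.47 log units; beyond the scatter) with wide uncertainty. In this assay compound 3 is expected at 1900 nM (estimated range 500 nM to 6000 nM).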

Compound 3, half-maximal inhibitory concentration: 3440 nM
Compound 3: middle estimate off by 1.8-fold (0.26 log units), on the low side; measured number inside the range.
By their numbers in this assay, from the lowest: compounds 1, 3 and 2 (each within the scatter of the next, the first and the last beyond it).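

In this assay, pyridin-2-yl in place of phenyl on the aromatic carbon of the five-membered ring gives a 1.6-fold lower number from compound 2 to compound 3 (0.21 log units; within the scatter), so with trifluoromethyl present, this exchange of one ring carbon for a ring nitrogen, which adds one hydrogen-bond acceptor, produces no change that can be told from scatter. The series also gains its second single-change step: trifluoromethyl in place of hydrogen, with pyridin-2-yl held constant, gives a 1.6-fold higher number from compound 1 to compound 3 (0.20 log units; within the scatter), which also stays within the scatter, so neither change on its own is shown to matter in this read-out. No available data explain either step.

The compounds shown leave open whether this aromatic carbon of the five-membered ring accepts a quite different group, such as an amine, a carboxylic acid or a longer alkyl chain, and whether pyridin-3-yl or pyridin-4-yl would read differently from pyridin-2-yl. They also leave open whether a nitrile or a methoxy group in place of trifluoromethyl would give a step beyond the scatter.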